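Sulfur for Nitrogen-Methyl on the Chain Terminus

The source may report more compounds than this note shows. Statements on the series, on what has been measured and on what is new or still open speak of the compounds shown alone.

Compound 1, `CSc1ccccc1CCCCCCC(=O)c1ncc(-c2ccccn2)o1`: 3.3 nM in an assay for inhibition of Fatty-acid amide hydrolase 1 (Rattus norvegicus); a higher number here means a weaker inhibitor, a lower number a stronger inhibitor
Compound 2, `CN(CCCCCC(=O)c1ncc(-c2ccccn2)o1)c1ccccc1`: 40 nM

Compound 2 holds the highest number of the two in this assay; its nearest neighbour is compound 1, at a 12-fold higher number from compound 1 to compound 2 (1.08 log units; beyond the scatter). Compound 3 is `O=C(CCCCCSc1ccccc1)c1ncc(-c2ccccn2)o1`, differing from compound 2 by phenylsulfanyl in place of methyl(phenyl)amino on a saturated chain carbon, five bonds along the chain from a carbonyl carbon. Within the data shown here, the only measured step, a 12-fold higher number from compound 1 to compound 2 (1.08 log units; beyond the scatter), exchanges a different group and bears on this change only loosely. Among the measured compounds shown here, no step within the scatter is recorded. Compound 3 is therefore expected to move back toward compound 1, estimated at 12 nM (range 3 nM to 50 nM), a step of a 3.3-fold lower number from compound 2 to compound 3 (0.52 log units; beyond the scatter).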

Compound 3, inhibition constant: 3 nM
Beside the measured number, compound 3's estimate is 4.0-fold (0.60 log units) above it, and the stated range covers the measured number.
By their numbers in this assay, from the lowest: compounds 3 and 1 (each within the scatter of the next); then compound 2.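

In this assay phenylsulfanyl in place of methyl(phenyl)amino gives a 13-fold lower number from compound 2 to compound 3 (1.12 log units; beyond the scatter) and so shows that this exchange on the saturated chain carbon alone carries a large step. Phenylsulfanyl in place of 2-(methylsulfanyl)benzyl gives a 1.1-fold lower number from compound 1 to compound 3 (0.04 log units; within the scatter) and so leaves these two different groups within the scatter of each other, with only methyl(phenyl)amino apart from them among the three compounds. Going by these compounds, whether phenoxy or phenylamino in the same place would stay with phenylsulfanyl or fall with methyl(phenyl)amino remains open. Nothing measured here accounts for the large step.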